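Fluoro in place of chloro on the shared core

The source may report more compounds than this note shows. Statements on the series, on what has been measured and on what is new or still open speak of the compounds shown alone.

- compound 1 `COc1ccc(NC(=O)Nc2cc(C)nc3ccccc23)cc1OC` gives 552 10^-6 cm/s
- compound 2 `COc1ccc(NC(=O)Nc2cc(C)nc3ccccc23)cc1Cl` gives 336 10^-6 cm/s

Among the measured compounds shown here, in an ADME assay for permeability, using PAMPA, at pH 7.4 (a lower number here means that the compound crosses the layer more slowly, a higher number that the compound crosses the layer faster), compound 2 gives 336 10^-6 cm/s as one of only two numbers so far, so its standing rests on a single comparison. That comparison is a 1.6-fold lower number from compound 1 to compound 2 (0.22 log units; within the scatter) and it comes with chloro in place of methoxy on an aromatic carbon.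

Compound 3 `COc1ccc(NC(=O)Nc2cc(C)nc3ccccc23)cc1F` differs from compound 2 at that same carbon: fluoro in place of chloro on an aromatic carbon in short, fluoro in place of chloro on an aromatic carbon. For the measured compounds named here, no measured step involves fluoro, so the one step available is only a loose guide. On that basis, no change beyond the scatter is expected in this assay and no direction is favoured. The expected step is a 1.0-fold higher number from compound 2 to compound 3 (0.02 log units; within the scatter) on this estimate. Compound 3 is estimated at 350 10^-6 cm/s with an expected range of 180 10^-6 cm/s to 680 10^-6 cm/s for now.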

Compound 3, apparent permeability: 50 10^-6 cm/s
Estimate against measurement, compound 3: 7.0-fold (0.85 log units) above; the measured number lies below the stated range.
By their numbers in this assay, from the lowest: compound 3; then compounds 2 and 1 (each within the scatter of the next).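

At this aromatic carbon, ortho to a methoxy group, the substituent can move the number in this assay well beyond the scatter: fluoro in place of chloro gives a 6.7-fold lower number from compound 2 to compound 3 (0.83 log units; beyond the scatter) even though one heavy atom simply replaces another and the counted donors and acceptors stay the same. Fluoro in place of methoxy gives an 11-fold lower number from compound 1 to compound 3 (1.04 log units; beyond the scatter) and the earlier chloro for methoxy step, a 1.6-fold lower number from compound 1 to compound 2 (0.22 log units; within the scatter) and so within the scatter, leaves fluoro as the one group of the three that stands apart. Nothing measured here accounts for the separation of the fluoro compound.

From the compounds shown here alone, whether a methyl group, a nitrile or an amine at this carbon would stand with fluoro or with chloro and methoxy remains open. Also open, going by these compounds, is whether fluoro in place of chloro would behave the same way at other carbons of the shared core.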